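The source may hold more compounds than are shown below. What is called first, only, known or untested is meant among the compounds shown, and "the series" means these compounds.

Measured so far in an assay for binding affinity to 5-hydroxytryptamine receptor 1F (Homo sapiens), read by radioligand binding; on this read-out lower numbers stand for stronger inhibition and higher numbers for weaker inhibition: compound 1 `CC(=O)Nc1cc2c(C3CCN(C)CC3)c[nH]c2cn1` gives 210 nM; compound 2 `COc1ccccc1C(=O)Nc1ccc2[nH]cc(C3CCN(C)CC3)c2n1` gives 20 nM; compound 3 `CN1CCC(c2c[nH]c3ccc(NC(=O)C4CCCCC4)nc23)CC1` gives 20 nM.

Compound 3 stands level with compound 2 within the scatter; together the two hold the lowest numbers of the three, and compound 1 lies beyond the scatter above both of them. Among the compounds with values here, the single measured change at the carbonyl carbon is the step of no change at the digits printed from compound 2 to compound 3 (within the scatter), cyclohexyl in place of 2-methoxyphenyl. Compound 4 `Cc1ccc(C(=O)Nc2ccc3[nH]cc(C4CCN(C)CC4)c3n2)cc1` differs from compound 3 by 4-methylphenyl in place of cyclohexyl on a carbonyl carbon. Within the data shown here, only the step from compound 2 to compound 3 bears on this change, and it left the number unmoved within the scatter; the two substituents so far tried at the carbonyl carbon, one aromatic and one not, read alike. The step of a 1.3-fold higher number from compound 3 to compound 4 (0.10 log units; within the scatter) from compound 3 to compound 4 in this assay is therefore expected to be none beyond the scatter. Compound 4 is estimated at 25 nM with a range of 8 nM to 80 nM because no change at the digits printed from compound 2 to compound 3 (within the scatter) gave no change at that position.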

Compound 4, inhibition constant: 12 nM
Compound 4: middle estimate off by 2.1-fold (0.32 log units), on the high side; low and high end bracket the measured number.
By their numbers in this assay, from the lowest: compounds 4, 2 and 3 (each within the scatter of the next); then compound 1.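

In this assay, 4-methylphenyl on the carbonyl carbon whose other neighbour is the amide-type nitrogen gives a 1.7-fold lower number from compound 3 to compound 4 (0.22 log units; within the scatter), and against the 2-methoxyphenyl group it gives a 1.7-fold lower number from compound 2 to compound 4 (0.22 log units; within the scatter). The earlier comparison rested on one pair, whereas three groups now read alike at this position: one non-aromatic six-membered ring and two differently substituted aromatic six-membered rings. No available evidence accounts for this level reading.

Still open, going by these compounds, is whether that level holds for groups on the carbonyl carbon other than six-membered carbon rings, such as a longer alkyl chain, a primary amine or a carboxylic acid. The compounds shown also leave open how the 2-methoxyphenyl and 4-methylphenyl groups would read with their substituents moved elsewhere on the aromatic ring.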